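This account rests on a few compounds, and the source may have more. Where it says the series, first, only, none or still open, it means among the compounds named here.

For the measured compounds named here, in a functional assay on LoVo cells (Homo sapiens) for inhibition, read by MTT assay, with a stated time of 72 h (on this read-out lower numbers stand for stronger inhibition and higher numbers for weaker inhibition), compound 2 (`C=C(Br)C(=O)Nc1cccc(/C=C/C(=O)Nc2cc(OC)c(OC)c(OC)c2)c1`) gives 140 nM and holds the lower of the two numbers so far, well under compound 1 (`COc1cccc(/C=C/C(=O)Nc2cc(OC)c(OC)c(OC)c2)c1`) at 43000 nM on this read-out. Going by the values given here, compound 3 (`COc1cc(NC(=O)/C=C/c2cccc(N)c2)cc(OC)c1OC`) takes compound 2 back to a simpler form through hydrogen in place of (1-bromoethenyl)carbonyl on a nitrogen on an aromatic ring as its only change, so hydrogen stands in place of (1-bromoethenyl)carbonyl on the nitrogen and a plain amino group remains. Among the compounds with values here, one measured step bears on this: a 310-fold lower number from compound 1 to compound 2 (2.49 log units; beyond the scatter) came with ((1-bromoethenyl)carbonyl)amino in place of methoxy on an aromatic carbon, a large step beyond the scatter. Within the data shown here, compound 3 carries neither that group nor the methoxy, and no measurement yet compares amino with methoxy. The expected change is a 180-fold higher number from compound 2 to compound 3 (2.25 log units; beyond the scatter) and so a large rise that undoes most of the earlier drop. For compound 3 the estimate is 25000 nM (range 6000 nM to 100000 nM).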

Compound 3, half-maximal inhibitory concentration: 45200 nM
The estimate for compound 3 lay 1.8-fold (0.26 log units) below the measured number; the measured number falls inside the stated range.
By their numbers in this assay, from the lowest: compound 2; then compounds 1 and 3 (each within the scatter of the next).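

In this assay, taking the (1-bromoethenyl)carbonyl off the nitrogen gives a 320-fold higher number from compound 2 to compound 3 (2.51 log units; beyond the scatter), so the low number of compound 2 depends on that group and not merely on a nitrogen standing at this place. The plain amino group does not bring that gain, since a 1.1-fold higher number from compound 1 to compound 3 (0.02 log units; within the scatter), leaving amino and methoxy indistinguishable here. Nothing available explains why the (1-bromoethenyl)carbonyl group has so large an effect.

The compounds shown leave open which part of that group matters: the bromine, the double bond or the carbonyl. A propenoyl group, which lacks the bromine, or a plain acetyl group on the same nitrogen would help separate these parts.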